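The source may hold more compounds than are shown below. What is called first, only, known or untested is meant among the compounds shown, and "the series" means these compounds.

Measured so far:
- compound 1, `O=C(O)c1ccc(N(C(=O)CCCCCBr)c2ccc(C(=O)O)cc2)cc1`: 12%
- compound 2, `CCCCCCCCCCOc1cc(OCCCCCCCCCC)cc(OCCCCCCO/N=C(/c2ccc(C(=O)O)cc2)c2cccc(C(=O)O)c2)c1`: 34%

Both numbers come from an assay on isolated protein for binding affinity to P-selectin (Homo sapiens), read by ELISA, tested at 500 uM; a lower number here means less inhibition, a higher number more inhibition at the concentration tested (going by the name of the read-out). Compound 1 stands at the lower of the two values; compound 2 gives 34%, a number that lies beyond the scatter above compound 1, so the two compounds are told apart by this assay. Compound 3, `O=C(O)c1ccc(N(C(=O)CCCCCBr)c2cccc(C(=O)O)c2)cc1`, has not been measured. It keeps every atom of compound 1 but joins them differently: 3-carboxyphenyl in place of 4-carboxyphenyl on an amide-type nitrogen. No step of this exact kind has been measured among the compounds shown, so there is no direct guide to its size. Among the measured compounds shown here, since compound 1 gives 12% and only one carboxyl group moves its position on one ring, the step is expected to be small, in either direction, and likely not beyond the scatter: a number 3 percentage points higher from compound 1 to compound 3 (within the scatter). Compound 3 is therefore estimated at 15%, in the range 4% to 32%.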

Compound 3, a percentage reported as inhibition, at one concentration (the size of the read-out at that concentration, not a potency): 19%
Beside the measured number, compound 3's estimate is 4 percentage points below it, and the stated range covers the measured number.
By their numbers in this assay, from the lowest: compounds 1 and 3 (each within the scatter of the next); then compound 2.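

Among the compounds shown here, putting 3-carboxyphenyl in place of 4-carboxyphenyl on the amide-type nitrogen gives the first step that can be read at this position: in this assay it is a number 7 percentage points higher from compound 1 to compound 3 (within the scatter) at the single concentration tested. With the same atoms joined differently, this assay does not tell the two compounds apart, so at this position it gives no sign that the carboxyl group's place on this ring matters. Nothing available bears on what lies behind this result.

Compound 2 differs from both in more than one place, so it cannot show what a single change at this position would do. Still open, on these data alone, is whether a tetrazole in place of the carboxylic acid on this ring, or a longer chain on the carbonyl of the shared core, would move the number beyond the scatter.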